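The compounds below may be only part of what the source reports. "The series", "measured", "known", "first", "only" and "open" are said of these compounds alone.

Working notes on the series. In an ADME assay on Vero cells (Chlorocebus sabaeus) for cytotoxicity, read by MTT assay, with a stated time of 72 h (a lower number here means that less compound is tolerated, a higher number that more compound is tolerated), compound 2 (`Cc1ccc(C(=O)N2CCN(c3nc(=O)c4cc(C(F)(F)F)cc([N+](=O)[O-])c4s3)CC2)cc1`) gives > 125000 nM, which is a limit and not a number. Compound 1 (`CSCC(=O)N1CCN(c2nc(=O)c3cc(C(F)(F)F)cc([N+](=O)[O-])c3s2)CC1`) gives > 125000 nM, also a limit. Compound 3 (`CC1COC2(CCN(c3nc(=O)c4cc(C(F)(F)F)cc([N+](=O)[O-])c4s3)CC2)O1`) gives > 125000 nM, again a limit. Compound 2 therefore has no measured number and shares its position with the other two: the limit of > 125000 nM in this assay, at which 3 of the 3 values shown sit.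

The next change gives compound 4 (`O=C(C1CCCCC1)N1CCN(c2nc(=O)c3cc(C(F)(F)F)cc([N+](=O)[O-])c3s2)CC1`), with cyclohexyl in place of 4-methylphenyl on a carbonyl carbon. For the measured compounds named here, the one measured step at this carbonyl carbon is a step that the two limits leave unreadable from compound 1 to compound 2, so it offers no size to carry over. Going by the values given here, compound 3 differs from compound 2 by more than one group and adds no measured step. No step beyond the scatter is expected in this assay, in either direction, and the expected change is a step that the limit leaves unreadable from compound 2 to compound 4. A further limit is the most likely report. For compound 4 the estimated value is 130000 nM, with an expected range of 60000 nM to 260000 nM.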

Compound 4, half-maximal cytotoxic concentration: 88700 nM
Beside the measured number, compound 4's estimate is 1.5-fold (0.17 log units) above it; the range from low to high includes it.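

In this assay compound 4 is the first compound shown to give a number rather than a limit, so a change on this carbonyl carbon can bring the reading inside the range of the assay: the limit of > 125000 nM in this assay, at which 3 of the 4 values shown sit.

The change shows an at least 1.4-fold lower number from compound 2 to compound 4 (0.14 log units; that floor lies within the scatter), and cyclohexyl in place of (methylsulfanyl)methyl shows an at least 1.4-fold lower number from compound 1 to compound 4 (0.14 log units; that floor lies within the scatter). Both are floors, so the true sizes stay unknown and neither is shown to exceed the scatter, while the step between the two limits of the earlier compounds cannot be read.

On these data alone, how far the number would move with an amine, a carboxylic acid or a longer chain on this carbonyl carbon remains open. Also open, as far as these compounds go, is whether cyclohexyl itself, rather than any saturated ring, goes with the measured number.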